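A few compounds are considered here, and "the series" means these few. Any claim that something is new, unique, unknown or untested is made for them only; others in the source may bear on it.

Measured so far:
compound 1, `CNC(=O)CCCCCCCn1nc(-c2ccc3oc(N)nc3c2)c2c(N)ncnc21`, 8360 nM
compound 2, `Nc1ncnc2c1c(-c1cnc3[nH]ccc3c1)nn2CCCCCCC(=O)NO`, 50000 nM

Both compounds were tested in a functional assay on A549 cells (Homo sapiens) for inhibition, read by MTT assay, with a stated time of 72 h; a higher number here means a weaker inhibitor, a lower number a stronger inhibitor. In this assay compound 1 gives 8360 nM, the lower of the two numbers shown. Compound 2 gives 50000 nM, a higher number, and the gap between these two lies beyond the usual scatter. Within the data shown here, compound 1 and compound 2 differ in more than one place, so no single step between them can be read from these two values.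

Compound 3, `Nc1nc2cc(-c3nn(CCCCC(=O)NO)c4ncnc(N)c34)ccc2o1`, has not yet been measured in this assay. It is reached from compound 1 by one change:

hydroxycarbamoyl in place of 3-(methylcarbamoyl)propyl on a saturated chain carbon, four bonds along the chain from an aromatic nitrogen

The chain that carries the end group becomes shorter, and the end group itself changes. Nothing already measured shows how this change, on this core, plays out in this assay. Among the measured compounds shown here, the one other compound with a hydroxycarbamoyl end, compound 2, sits on a different core and gives 50000 nM, which offers only a loose hint. The step from compound 1 to compound 3 is expected to be modest and toward a higher number, a 1.8-fold higher number from compound 1 to compound 3 (0.25 log units; within the scatter), though it could fall within the scatter. Compound 3 is expected to give about 15000 nM, in a range from 4000 nM to 60000 nM.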

Compound 3, half-maximal inhibitory concentration: > 100000 nM
Compound 3: no number, only a limit (the forecaster's own chance of this, stated with the estimate: 25%); middle value at least 6.6-fold (0.82 log units) from the limit.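

In this assay compound 3 gives > 100000 nM, which is a limit of the assay and not a number. Compound 2 sits on a different core, so it could only hint at what a hydroxycarbamoyl end does, but this pair shares one core and gives a direct reading: hydroxycarbamoyl in place of 3-(methylcarbamoyl)propyl, on a saturated chain carbon, four bonds along the chain from an aromatic nitrogen, is a large step in the weakening direction, an at least 11-fold higher number from compound 1 to compound 3 (1.07 log units; beyond the scatter). This shows that the end of the chain is not a silent place on this core in this cell assay, and the full size of the step stays unknown, with only a minimum available from this reading: the limit of > 100000 nM in this assay, at which 1 of the 3 values shown sits.

The compounds shown leave open whether the shorter chain, the new end group or the two together account for the step, as both changed at once in this single comparison. A longer chain ending in hydroxycarbamoyl on this core, or a shorter chain ending in a carboxylic acid or an amine, would help to pull these two effects apart.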